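Extending the Aryl Substituent: Expecting the Value for Compound 4

The compounds below may be only part of what the source reports. "The series", "measured", "known", "first", "only" and "open" are said of these compounds alone.

Three compounds have been measured in an ADME assay on MDCK cells (Canis lupus familiaris) for cytotoxicity, read by microscopy, with a stated time of 48 h; on this read-out lower numbers stand for higher toxicity in this test and higher numbers for lower toxicity in this test:

compound 1, `C[C@H]1[C@H](NCc2ccc(C(C)(C)C)s2)C[C@H]2C[C@@H]1C2(C)C`: 780 nM
compound 2, `Cc1ccc(CN[C@@H]2C[C@H]3C[C@@H]([C@H]2C)C3(C)C)s1`: 780 nM
compound 3, `C[C@H]1[C@H](NCc2ccc(Br)s2)C[C@H]2C[C@@H]1C2(C)C`: 43000 nM

Compound 3 stands highest of the three numbers. The step of a 55-fold higher number from compound 1 to compound 3 (1.74 log units; beyond the scatter) and the step of a 55-fold higher number from compound 2 to compound 3 (1.74 log units; beyond the scatter) are both large, whereas the step of no change at the digits printed from compound 1 to compound 2 (within the scatter) lies within the scatter. Compound 4, `C[C@H]1[C@H](NCc2ccc(-c3ccc(Br)s3)s2)C[C@H]2C[C@@H]1C2(C)C`, differs from compound 3 in one place: 5-bromothiophen-2-yl in place of bromo on an aromatic carbon. Among the measured compounds shown here, no measured step covers this change directly. What the measured steps show is that a bromo group gives a far higher number than either a methyl or a tert-butyl group at that aromatic carbon, so a carbon-based group in this position has gone with a lower number in this assay. Compound 4 carries a carbon-based ring group in place of the bromo, so a move towards lower numbers in this assay is expected, with the estimated step of an 11-fold lower number from compound 3 to compound 4 (1.03 log units; beyond the scatter). Compound 4 is therefore estimated at 4000 nM, with a range from 800 nM to 25000 nM.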

Compound 4, minimum cytotoxic concentration: 780 nM
For compound 4 the middle estimate is 5.1-fold (0.71 log units) above the measured one; measured number outside the range, below it.
By their numbers in this assay, from the lowest: compounds 1, 2 and 4 (each within the scatter of the next); then compound 3.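

In this assay the step of a 55-fold lower number from compound 3 to compound 4 (1.74 log units; beyond the scatter) shows that the bromine carried by the 5-bromothiophen-2-yl group does not keep the high number seen with bromo alone on this aromatic carbon. There is also no change at the digits printed from compound 2 to compound 4 (within the scatter) and no change at the digits printed from compound 1 to compound 4 (within the scatter) at this position, so among these four compounds methyl, tert-butyl and 5-bromothiophen-2-yl stand together and only bromo stands apart, even though the entering group adds a five-membered aromatic ring. Nothing else measured here accounts for this pattern.

The compounds shown leave open whether the high number is particular to bromo or would also appear with chloro, an amine or a carboxylic acid on this carbon. They also leave open where an unsubstituted thiophen-2-yl group would stand.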